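A few compounds are considered here, and "the series" means these few. Any claim that something is new, unique, unknown or untested is made for them only; others in the source may bear on it.

Measured compounds:
Compound 1, `COc1ccc2nc(C(F)(F)F)cc(OCC(=O)Nc3cc(C)cc(C)c3)c2c1`, 15000 nM
Compound 2, `COc1ccc2nc(C)cc(OCC(=O)Nc3cc(C)ccc3OC)c2c1`, 9500 nM

Of the compounds shown here, two have been measured in a physicochemical assay for solubility, in phosphate buffer, measured as kinetic solubility, with a stated time of 1 h, at pH 7.4; a higher number here means a more soluble compound, a lower number a less soluble compound. Compound 1 `COc1ccc2nc(C(F)(F)F)cc(OCC(=O)Nc3cc(C)cc(C)c3)c2c1` gives 15000 nM, and compound 2 `COc1ccc2nc(C)cc(OCC(=O)Nc3cc(C)ccc3OC)c2c1` gives 9500 nM. Compound 2 holds the lower of the two numbers, but its gap to compound 1 lies within the scatter of the method, so the two values cannot be told apart with confidence.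

Compound 3 `COc1ccc2nc(C)cc(OCC(=O)Nc3ccncn3)c2c1` has not yet been measured in this assay. It differs from compound 2 in a single place: pyrimidin-4-yl in place of 2-methoxy-5-methylphenyl on an amide-type nitrogen. The aryl group that leaves, and the heteroaryl group that enters, sit on the amide-type nitrogen whose other neighbour is the carbonyl carbon. For the measured compounds named here, no measured pair in this set shows a change of this kind, so the expectation rests on the change itself and on compound 2 alone.

The step from compound 2 to compound 3 in this assay is expected to be modest and upward, a 2.6-fold higher number from compound 2 to compound 3 (0.42 log units; beyond the scatter), though a result within the scatter would not surprise. Compound 3 is estimated at 25000 nM, with a range from 8000 nM to 80000 nM.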

Compound 3, solubility: 27500 nM
Estimate against measurement, compound 3: 1.1-fold (0.04 log units) below; the measured number falls inside the stated range.
By their numbers in this assay, from the lowest: compounds 2, 1 and 3 (each within the scatter of the next, the first and the last beyond it).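

In this assay, the amide-type nitrogen proves to be a place where the read-out responds: pyrimidin-4-yl in place of 2-methoxy-5-methylphenyl gives a 2.9-fold higher number from compound 2 to compound 3 (0.46 log units; beyond the scatter), a modest step. For the compounds shown here, this is the first comparison in the set between compounds that differ in one place only, so it provides the first reading of a single change, and that change lies beyond the scatter. Nothing measured alongside these numbers bears on what lies behind the step.

This single exchange replaces a carbon-only aromatic ring bearing methoxy and methyl groups with a smaller aromatic ring holding two hetero atoms, so the step cannot be divided among those differences, and a plain phenyl or a pyridinyl group on the same nitrogen would be needed to separate them. Also open, on these data alone, is how the read-out would respond to a non-aromatic group on this nitrogen, such as a chain ending in an amine or a carboxylic acid, and whether pyrimidin-4-yl would give a similar step on the core of compound 1.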